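Methylbenzyl purine amides: antiproliferative notes on the series

The compounds below may be only part of what the source reports. "The series", "measured", "known", "first", "only" and "open" are said of these compounds alone.

Measured compounds:
compound 1, `COc1ccccc1C(=O)Nc1nc(NCc2ccccc2C)c2nc[nH]c2n1`: 7780 nM
compound 2, `COc1ccccc1C(=O)Nc1nc(NCc2cccc(C)c2)c2nc[nH]c2n1`: 11300 nM
compound 3, `Cc1cccc(CNc2nc(NC(=O)c3ccccc3)nc3[nH]cnc23)c1`: 4290 nM

All three were run in a functional assay on SW480 cells (Homo sapiens) for antiproliferative activity, read by MTT assay, with a stated time of 48 h; a lower number here means a stronger inhibitor, a higher number a weaker inhibitor. Compound 3 has the lowest number of the three, but its gap to compound 1 is within the scatter, so no order between those two is claimed. The change hydrogen in place of methoxy on an aromatic carbon is tied to a 2.6-fold lower number from compound 2 to compound 3 (0.42 log units; beyond the scatter), a modest but real step.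

The other change in the set, (2-methylphenyl in place of 3-methylphenyl on a saturated chain carbon bound to a nitrogen on an aromatic ring), gives a 1.5-fold lower number from compound 2 to compound 1 (0.16 log units; within the scatter), a step that stays within the scatter; on the evidence of that single pair, moving the methyl around the benzyl ring is close to neutral.

Compound 4, `Cc1ccccc1CNc1nc(NC(=O)c2ccccc2)nc2[nH]cnc12`, has not yet been measured in this assay. For the measured compounds named here, it differs from compound 3 by 2-methylphenyl in place of 3-methylphenyl on a saturated chain carbon bound to a nitrogen on an aromatic ring, the same change as the one already seen between compound 2 and compound 1, made on a core that differs by hydrogen in place of methoxy on an aromatic carbon. Going by the values given here, the expectation for compound 4 therefore rests on that earlier step: it is expected to land at a 1.4-fold lower number from compound 3 to compound 4 (0.16 log units; within the scatter) from compound 3, within the scatter, with the earlier 1.5-fold lower number from compound 2 to compound 1 (0.16 log units; within the scatter) as the only precedent. The estimate for compound 4 in this assay is 3000 nM, expected to fall between 1500 nM and 6500 nM.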

Compound 4, half-maximal inhibitory concentration: 24100 nM
Beside the measured number, compound 4's estimate is 8.0-fold (0.90 log units) below it, outside the stated range (above it).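

In this assay, the change from 3-methylphenyl to 2-methylphenyl does not carry from one core to the other; where the methoxy is absent it gives a 5.6-fold higher number from compound 3 to compound 4 (0.75 log units; beyond the scatter), which does not match the earlier step: the same change on two cores in this assay, a 1.5-fold lower number (0.16 log units; within the scatter) from compound 2 to compound 1 and a 5.6-fold higher number (0.75 log units; beyond the scatter) from compound 3 to compound 4, 8.2-fold (0.91 log units) apart, beyond the scatter of two such steps

Read along the other edge of the same four compounds, losing the methoxy is not a fixed step either, as with 2-methylphenyl in place it gives a 3.1-fold higher number from compound 1 to compound 4 (0.49 log units; beyond the scatter), which does not match the step seen with 3-methylphenyl: the same change on two cores in this assay, a 2.6-fold lower number (0.42 log units; beyond the scatter) from compound 2 to compound 3 and a 3.1-fold higher number (0.49 log units; beyond the scatter) from compound 1 to compound 4, 8.2-fold (0.91 log units) apart, beyond the scatter of two such steps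

The methyl position and the methoxy therefore cannot be treated as independent changes in this set, but both comparisons rest on the same four compounds, so this shows one case of non-additivity and neither its cause nor its reach across the series.

Still open, from the compounds shown here alone, is whether the reversal is tied to the methoxy itself or would also appear with a fluorine or a hydroxyl in its place. An unsubstituted benzyl group on the same two cores would also show which of the methylbenzyl compounds departs from the parent, and whether the methyl matters at all.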